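Dropping the Chloro from the Sulfonyl Phenyl Ring

A few compounds are considered here, and "the series" means these few. Any claim that something is new, unique, unknown or untested is made for them only; others in the source may bear on it.

compound 1, `CC(O)(CS(=O)(=O)c1ccc(Cl)cc1)c1nc(-c2ccc([N+](=O)[O-])c(C(F)(F)F)c2)no1`: 91000 nM
compound 2, `CC(O)(CS(=O)(=O)c1ccc(Br)cc1)c1nc(-c2ccc(Cl)cc2)no1`: > 100000 nM

Of the compounds shown here, two have been measured in a functional assay on DU-145 cells (Homo sapiens) for cytotoxicity, read by MTT assay; a higher number here means a weaker inhibitor, a lower number a stronger inhibitor. Compound 1 `CC(O)(CS(=O)(=O)c1ccc(Cl)cc1)c1nc(-c2ccc([N+](=O)[O-])c(C(F)(F)F)c2)no1` gives 91000 nM in this assay, a weak result. For compound 2 `CC(O)(CS(=O)(=O)c1ccc(Br)cc1)c1nc(-c2ccc(Cl)cc2)no1` the outcome in this assay is only a limit, > 100000 nM, and not a number. Compound 1 therefore stands as the single numbered result among the two shown. The other result sits at the limit (the limit of > 100000 nM in this assay, at which 1 of the 2 values shown sits).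

Compound 3 `CC(O)(CS(=O)(=O)c1ccccc1)c1nc(-c2ccc([N+](=O)[O-])c(C(F)(F)F)c2)no1` has not yet been measured. It differs from compound 1 by hydrogen in place of chloro on an aromatic carbon. Among the measured compounds shown here, no step between two measured compounds is available to guide this change, so the expectation rests on the weak result of compound 1 alone. The step from compound 1 to compound 3 in this assay is expected to be small, either none beyond the scatter or a slight move toward weaker inhibition, as a 1.3-fold higher number from compound 1 to compound 3 (0.12 log units; within the scatter). Compound 3 is accordingly expected to give about 120000 nM in this assay, with a range from 50000 nM to 300000 nM, and a real chance that only a limit is reported.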

Compound 3, half-maximal inhibitory concentration: > 100000 nM
Compound 3 ended at the assay's limit; the forecaster's own chance of this, stated with the estimate: 55%; the middle value is on the limit's open side.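

In this assay, compound 3 gives > 100000 nM, which is a limit of the assay and not a number. Hydrogen in place of chloro on the aromatic carbon para to a large group gives an at least 1.0-fold higher number from compound 1 to compound 3 (0.04 log units; that floor lies within the scatter), so the change has only a floor, and that floor does not separate the two compounds. The earlier compounds offered no single-place comparison at all, whereas this pair shows that going from (4-chlorophenyl)sulfonyl to phenylsulfonyl brings no gain in this cell read-out and leaves the new compound at the limit, where most of the series now sits: the limit of > 100000 nM in this assay, at which 2 of the 3 values shown sit.

From the compounds shown here alone, how far compound 3 lies past that limit stays unknown, so whether the chloro contributes anything to the weak activity of compound 1 cannot be read from these values. Also open, going by these compounds, is whether a different group at this position, such as an amine, a methoxy group or a carboxylic acid, would bring the shared core to a clearly stronger value in this assay.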